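Compound 4: hexyl in place of 4-methylpentyl

A few compounds are considered here, and "the series" means these few. Any claim that something is new, unique, unknown or untested is made for them only; others in the source may bear on it.

Measured in a functional assay on MDA-MB-231 cells (Homo sapiens) for antiproliferative activity, read by sulforhodamine B assay; on this read-out lower numbers stand for stronger inhibition of growth and higher numbers for weaker inhibition of growth:
- compound 1 `CC(C)CCCOc1cccc(O)c1C(=O)/C=C/c1ccc(O)cc1`: 3480 nM.
- compound 2 `COc1cccc(OCCC(C)(C)C)c1C(=O)/C=C/c1ccc(O)cc1`: > 30000 nM, a limit of the assay and not a number.
- compound 3 `CC(C)(C)CCOc1cccc(O)c1C(=O)/C=C/c1ccc(C(=O)O)cc1`: 11200 nM.

Among the two actual numbers, compound 1 at 3480 nM stands lowest. Compound 3 at 11200 nM lies higher, and that gap is beyond the usual scatter. Compound 2 gives only a limit, so it cannot be placed against the other two.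

The next compound to be read is compound 4 `CCCCCCOc1cccc(O)c1C(=O)/C=C/c1ccc(O)cc1`, which has the same atoms as compound 1, joined differently. The change is propyl in place of isopropyl on a saturated chain carbon, three bonds along the chain from an oxygen on an aromatic ring. Cut one bond further out, the same difference reads 4-methylpentyl to hexyl.

Among the compounds with values here, no two measured compounds differ in one place alone, so the series offers no direct precedent for this change. The expectation in this assay therefore starts from compound 1 at 3480 nM, with no step beyond the scatter in either direction. The estimated move is a 1.1-fold higher number from compound 1 to compound 4 (0.06 log units; within the scatter), which is expected to stay within the scatter. For compound 4 the estimated value is 4000 nM, with an expected range of 1700 nM to 10000 nM.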

Compound 4, concentration for 50% growth inhibition: > 30000 nM
Compound 4 ended at the assay's limit; the forecaster's own chance of this, stated with the estimate: 5%; at least 7.5-fold (0.87 log units) between middle value and limit.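

In this assay compound 4 gives > 30000 nM, a limit of the assay and not a number. Swapping the two chain ends gives an at least 8.6-fold higher number from compound 1 to compound 4 (0.93 log units; beyond the scatter): propyl in place of isopropyl on a saturated chain carbon, three bonds along the chain from an oxygen on an aromatic ring, with the same atoms joined differently, so at this position activity in the core of compound 1 is sensitive to how the chain end is joined and not only to which atoms it holds. The printed step is a lower bound, and its full size cannot be read from the assay: the limit of > 30000 nM in this assay, at which 2 of the 4 values shown sit.

Within the data shown here, compounds 2 and 3 differ from compound 1 in more than one place, so they give no second reading of this change, and the result rests on the single pair of compound 1 and compound 4. Still open, on these data alone, is how an amine at the chain end, or a longer chain such as octyl, would read on the same core, and whether the isopropyl end keeps its advantage over propyl with a different group on the other ring.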